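A few compounds are considered here, and "the series" means these few. Any claim that something is new, unique, unknown or untested is made for them only; others in the source may bear on it.

Compound 1, with the structure `CC1=C(N2CC2)C(=O)C(CCCOC(N)=O)=C(N2CC2)C1=O`, carries a carbamate-bearing chain on one carbon of its quinone-like core. In a functional assay on L1210 cells (Mus musculus), with a stated time of 12 days (a lower number here means a less potent compound, a higher number a more potent compound, by a factor of ten per unit of this negative logarithm), compound 1 gives 5.93. Among the three measured compounds it sits within the scatter of compound 2 and clearly above compound 3. Compound 2 has the structure `CC1=C(N2CC2)C(=O)C(N2CC2)=C(N2CC2)C1=O` and gives 6.21; the step of a number 0.28 log units higher from compound 1 to compound 2 (within the scatter) counts as no real change. Compound 3 has the structure `CCC(OC)C1=C(N2CC2)C(=O)C(C)=C(N2CC2)C1=O` and gives 5.33; here the step of a number 0.60 log units lower from compound 1 to compound 3 (beyond the scatter) is a genuine, if modest, loss. Compound 4, the structure `CC1=C(N2CC2)C(=O)C(COc2ccccc2)=C(N2CC2)C1=O`, is not yet measured. It differs from compound 1 by phenoxy in place of 2-(carbamoyloxy)ethyl on a saturated chain carbon bound to a double-bonded ring carbon. Both measured steps from compound 1 also swapped the carbamate-bearing chain for something else, though on the double-bonded ring carbon itself, so they bear only loosely on this change: one produced nothing beyond the scatter, the other a modest drop. Within the data shown here, nothing among the measured compounds carries a phenoxy group. A small step is therefore expected, most likely downward or none beyond the scatter, giving an estimated a number 0.18 log units lower from compound 1 to compound 4 (within the scatter). For compound 4 the expected value in this assay is 5.75, estimated to fall between 5.25 and 6.25.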

Compound 4, logarithm of the reciprocal of the active concentration, log(1/C): 4.71
Estimate against measurement, compound 4: 1.04 log units above; measured number outside the range, below it.
By their numbers in this assay, from the lowest: compound 4; then compound 3; then compounds 1 and 2 (each within the scatter of the next).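

In this assay, among these compounds, phenoxy in place of 2-(carbamoyloxy)ethyl on a saturated chain carbon bound to a double-bonded ring carbon gives a number 1.22 log units lower from compound 1 to compound 4 (beyond the scatter) and is the only large step among the four compounds. The earlier steps shown here from compound 1, made on the double-bonded ring carbon itself, stayed within the scatter or were modest, so they did not show that a single exchange on this chain could cost so much. This chain position is therefore far from indifferent to what it carries, at least for this one pair, but nothing shown here explains the drop.

The exchange removes a carbamate and brings in a six-membered aromatic ring in one step, so the compounds shown cannot separate the loss of the one from the arrival of the other. A hydroxyl group, an amine or a plain ethyl group on the same saturated chain carbon would help to tell the two apart, as would a simple phenyl group without the ether oxygen.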